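The source may report more compounds than this note shows. Statements on the series, on what has been measured and on what is new or still open speak of the compounds shown alone.

Compounds measured so far in a functional assay on WM 266-4 cells (Homo sapiens) for antiproliferative activity, read by MTT assay, with a stated time of 24 h; on this read-out lower numbers stand for stronger inhibition of growth and higher numbers for weaker inhibition of growth:

compound 1 `Fc1ccccc1C1CC(c2ccc3c(c2)OCCO3)=NN1c1ccccc1` gives 9120 nM
compound 2 `Brc1ccc(C2CC(c3ccc4c(c3)OCCO4)=NN2c2ccccc2)cc1` gives 3010 nM

Of these two, compound 2 holds the lower number in this assay and so shows the stronger inhibition of growth. Among the compounds with values here, the one measured step is a 3.0-fold lower number from compound 1 to compound 2 (0.48 log units; beyond the scatter) and it came with 4-bromophenyl in place of 2-fluorophenyl on a saturated ring carbon.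

Compound 3 `Cc1ccc(C2CC(c3ccc4c(c3)OCCO4)=NN2c2ccccc2)cc1` has not yet been measured. It differs from compound 2 by methyl in place of bromo on an aromatic carbon, para to a large group methyl in place of bromo on an aromatic carbon and the same difference reads 4-bromophenyl to 4-methylphenyl. Within the data shown here, no measured step makes this exchange. Among the measured compounds shown here, the only guide to size is therefore a 3.0-fold lower number from compound 1 to compound 2 (0.48 log units; beyond the scatter) and it involved a different pair of groups. A step no larger than that one is expected, probably toward a higher number and possibly not beyond the scatter. Estimated in this way, the change is a 1.3-fold higher number from compound 2 to compound 3 (0.12 log units; within the scatter) as the expected step. In this assay the estimate for compound 3 is 4000 nM with an expected range from 1500 nM to 10000 nM as its bounds.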

Compound 3, concentration for 50% growth inhibition: 2530 nM
Compound 3: middle estimate off by 1.6-fold (0.20 log units), on the high side; the range from low to high includes it.
By their numbers in this assay, from the lowest: compounds 3 and 2 (each within the scatter of the next); then compound 1.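

In this assay, methyl in place of bromo on an aromatic carbon, para to a large group, gives a 1.2-fold lower number from compound 2 to compound 3 (0.08 log units; within the scatter), so this exchange leaves the read-out within the scatter, a comparison at this one place that the earlier pair could not offer. The distance from compound 1 also no longer rests on bromo alone: the 4-methylphenyl group gives a 3.6-fold lower number from compound 1 to compound 3 (0.56 log units; beyond the scatter), which stands beside the earlier 3.0-fold lower number from compound 1 to compound 2 (0.48 log units; beyond the scatter), and both steps lie beyond the scatter. Nothing available explains why these two groups read alike at this position.

The steps from compound 1 change both the group and its place on the aryl ring, so the compounds shown cannot tell which of the two carries the difference. On these data alone, it also remains open whether the tolerance seen here extends beyond bromo and methyl to a group of another kind at the same place, such as an amine, a carboxylic acid or a longer alkyl chain.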